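The source may hold more compounds than are shown below. What is called first, only, known or untested is meant among the compounds shown, and "the series" means these compounds.

Compound 1 `O=C(CSc1nc(Nc2ccccc2)c2ccccc2n1)Nc1cccc(Br)c1` gave 11400 nM in a functional assay on PC-3 cells (Homo sapiens) for inhibition, read by MTT assay, with a stated time of 72 h; a higher number here means a weaker inhibitor, a lower number a stronger inhibitor.
Compound 2 `O=C(CSc1nc(Nc2ccccc2)c2ccccc2n1)Nc1ccc(Br)cc1` gave 8450 nM in this assay.
Compound 3 `C=CC(=O)Nc1cccc(NC(=O)CSc2nc(Nc3ccccc3F)c3ccccc3n2)c1` gave 9340 nM in this assay.

Compound 3 carries an acrylamide on the ring attached to the amide nitrogen and a fluoro on the anilino ring. Its number in this assay lies within the scatter of both compound 2 and compound 1, so none of the three compounds is set apart from the others.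

Compound 4 `C=CC(=O)Nc1cccc(NC(=O)CSc2nc(Nc3ccccc3C)c3ccccc3n2)c1` keeps the whole of compound 3 except for one change: methyl in place of fluoro on an aromatic carbon. The change sits on an aromatic carbon of a six-membered aromatic ring of carbon only, ortho to a large group, so that 2-fluorophenyl becomes 2-methylphenyl.

Among the compounds with values here, only one measured step exists here, a 1.3-fold lower number from compound 1 to compound 2 (0.13 log units; within the scatter), and it concerns a bromine moved on the other aryl ring, not the anilino ring that changes in compound 4. Within the data shown here, no measured step touches the substituent that is exchanged. The data therefore give no reason to expect a step beyond the scatter in this assay in either direction.

Compound 4 is accordingly expected to give about 9000 nM, with a range from 4500 nM to 18000 nM. That estimate means an expected step of a 1.0-fold lower number from compound 3 to compound 4 (0.02 log units; within the scatter), within the scatter.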

Compound 4, half-maximal inhibitory concentration: 23200 nM
Compound 4: the middle estimate sits 2.6-fold (0.41 log units) below what was measured, and the stated range ends below it.
By their numbers in this assay, from the lowest: compounds 2, 3 and 1 (each within the scatter of the next); then compound 4.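

In this assay, the exchange of 2-fluorophenyl for 2-methylphenyl gives a 2.5-fold higher number from compound 3 to compound 4 (0.40 log units; beyond the scatter), a modest step and the first in this set to lie beyond the scatter. Within the data shown here, the earlier compounds showed no step of this kind, as their numbers all lie within the scatter of one another and the one measured step concerned a bromine on the other aryl ring. This place on an aromatic carbon, ortho to a large group, therefore responds to a change of a single heavy atom, even though fluoro and methyl have the same counts of heavy atoms, hydrogen-bond donors and hydrogen-bond acceptors, and no measurement among these data accounts for the step.

The compounds shown leave open how the number moves with other groups at this place, such as a chlorine, a methoxy group or plain hydrogen, and thus whether the step follows from the arrival of the methyl or from the loss of the fluoro. They also leave open whether the same exchange would give a step of similar size on a compound with a bromine in place of the acrylamide, as in the bromophenyl amides compound 1 and compound 2.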